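Swapping dimethylamino for diethylamino on a longer chain

The source may hold more compounds than are shown below. What is called first, only, known or untested is meant among the compounds shown, and "the series" means these compounds.

Measured compounds in a functional assay on A549 cells (Homo sapiens) for antiproliferative activity, read by MTT assay, with a stated time of 48 h; a lower number here means a stronger inhibitor, a higher number a weaker inhibitor:
Compound 1 `CN(C)CCCn1c(N)c(-c2nc3ccccc3[nH]2)c2nc(C#N)c(C#N)nc21` gives 10400 nM.
Compound 2 `CCN(CC)CCCn1c(N)c(-c2nc3ccccc3[nH]2)c2nc(C#N)c(C#N)nc21` gives 25300 nM.
Compound 3 `CN(C)CCCCn1c(N)c(-c2nc3ccccc3o2)c2nc(C#N)c(C#N)nc21` gives 5470 nM.

Compound 1 and compound 2 share one core and differ only in diethylamino in place of dimethylamino on a saturated chain carbon, three bonds along the chain from an aromatic nitrogen. That change gave a 2.4-fold higher number from compound 1 to compound 2 (0.39 log units; beyond the scatter), so the diethylamino partner is the weaker inhibitor of the pair. Compound 3 carries a different core; the difference between the two cores is not broken down here. Its number in this assay sits within the scatter of compound 1 and is lower than that of compound 2.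

Compound 4 `CCN(CC)CCCCn1c(N)c(-c2nc3ccccc3o2)c2nc(C#N)c(C#N)nc21` has not been measured. It differs from compound 3 in diethylamino in place of dimethylamino on a saturated chain carbon, four bonds along the chain from an aromatic nitrogen. The two places are not identical: in the first pair the carbon is three bonds along the chain from an aromatic nitrogen, in the second it is four, so this is the same kind of change rather than the same one. Resting on the step from compound 1 to compound 2, the expectation is that compound 4 moves upward by a 2.4-fold higher number from compound 3 to compound 4 (0.38 log units; beyond the scatter) in this assay. Compound 4 is therefore estimated at 13000 nM, expected to lie between 6000 nM and 30000 nM.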

Compound 4, half-maximal inhibitory concentration: 9390 nM
Estimate against measurement, compound 4: 1.4-fold (0.14 log units) above; measured number inside the range.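

In this assay, putting diethylamino in place of dimethylamino on the core of compound 3 gave a 1.7-fold higher number from compound 3 to compound 4 (0.23 log units; within the scatter), so the two compounds of this pair cannot be told apart. Set beside the earlier pair, the two steps do not differ by more than repeat measurements would: the same change on two cores in this assay, a 2.4-fold higher number (0.39 log units; beyond the scatter) from compound 1 to compound 2 and a 1.7-fold higher number (0.23 log units; within the scatter) from compound 3 to compound 4, 1.4-fold (0.15 log units) apart, within the scatter of two such steps. Among the compounds shown here, this shows that the change carried from one core to the other without a detectable difference in the size of its step, but it rests on only two pairs; the core and the chain length differ together between them, so neither can be judged alone, and nothing follows for any further core.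

The compounds shown leave open whether the same step would appear with another amine at the chain end, such as a morpholine or a primary amine. They also leave open what the swap would do on a longer chain.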